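This account rests on a few compounds, and the source may have more. Where it says the series, first, only, none or still open, it means among the compounds named here.

Measured so far in a functional assay on PC-3 cells (Homo sapiens) for inhibition, read by sulforhodamine B assay, with a stated time of 48 h; on this read-out higher numbers stand for weaker inhibition of growth and lower numbers for stronger inhibition of growth:

Compound 1, `Cc1ccc(-c2c(CNC(C)(C)C)c(C(=O)O)nn2-c2ccccc2)cc1`: compound 1 gives only the assay limit > 688000 nM.
Compound 2, `COc1ccc(-c2c(CNC(C)(C)C)c(C(=O)O)nn2-c2ccccc2)cc1`: compound 2 gives only the assay limit > 659000 nM.
Compound 3, `Cc1ccc(-c2c(CNC(C)(C)C)c(C(=O)O)nn2-c2ccc(Cl)cc2)cc1`: compound 3 gives only the assay limit > 629000 nM.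

Compound 4, `COc1ccc(-c2c(CNC(C)(C)C)c(C(=O)O)nn2-c2ccc(Cl)cc2)cc1`, has not yet been measured in this assay. It differs from compound 3 by methoxy in place of methyl on an aromatic carbon. The same change is made once more among these compounds, from compound 1 to compound 2, where it is methoxy in place of methyl on an aromatic carbon, and the place is described in the same words, so it is the same change. The step it made there is a step that the two limits leave unreadable from compound 1 to compound 2. Compound 1 sits at the limit of > 688000 nM in this assay, at which 1 of the 3 values shown sits. Compound 2 sits at the limit of > 659000 nM in this assay, at which 1 of the 3 values shown sits. The cores of the two pairs differ by chloro in place of hydrogen on an aromatic carbon, and the step between them is a step that the two limits leave unreadable from compound 1 to compound 3; compound 3 sits at the limit of > 629000 nM in this assay, at which 1 of the 3 values shown sits.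

For the measured compounds named here, with every value so far a limit, the step from compound 3 to compound 4 is expected to read a step that the limit leaves unreadable from compound 3 to compound 4, because compound 3 stands at the limit of > 629000 nM in this assay, at which 1 of the 3 values shown sits, and the same change elsewhere gave a step that the two limits leave unreadable from compound 1 to compound 2. Compound 4 is therefore estimated at 700000 nM, expected between 250000 nM and 2000000 nM, most likely again as a limit.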

Compound 4, concentration for 50% growth inhibition: > 605000 nM
Compound 4: a limit, no number; the forecaster's own chance of this, stated with the estimate: 85%; the middle value does not contradict the limit.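

In this assay compound 4 gives > 605000 nM, which is a limit. With limits on both sides, neither the step from compound 3 to compound 4 nor the step from compound 2 to compound 4 can be read. The compounds shown leave open whether methoxy in place of methyl or chloro in place of hydrogen changes the result in this assay at all.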